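The source may report more compounds than this note shows. Statements on the series, on what has been measured and on what is new or still open speak of the compounds shown alone.

Compound 1 `CC(=O)Oc1ccccc1C(=O)O[C@H]1CO[C@H]2[C@@H]1OC[C@H]2OC(=O)c1snnc1C` and compound 2 `CCC(=O)O[C@@H]1CO[C@H]2[C@@H]1OC[C@@H]2OC(=O)c1ccccc1OC(C)=O` share one core and differ only in the group attached to one carbonyl carbon. In an ADME assay on a cell-free system (plasma, Homo sapiens) for metabolic stability, with Plasma (Rattus norvegicus) as the target, read by HPLC, at pH 7.4 (on this read-out lower numbers stand for a shorter-lived compound and higher numbers for a longer-lived compound), compound 1 gives 0.0065 h, while compound 2 gives 0.011 h. Compound 2 holds the higher of the two numbers, but the step of a 1.7-fold higher number from compound 1 to compound 2 (0.23 log units; within the scatter) lies within the scatter, so the two compounds cannot be told apart on this read-out. Compound 3 `CC(=O)Oc1ccccc1C(=O)O[C@H]1CO[C@H]2[C@@H]1OC[C@H]2OC(=O)c1ccc(C)cc1` has not yet been measured. It differs from compound 2 by 4-methylphenyl in place of ethyl on a carbonyl carbon. For the measured compounds named here, the only measured step that bears on this change, a 1.7-fold higher number from compound 1 to compound 2 (0.23 log units; within the scatter), swapped the group on that same carbonyl carbon and left the half-life within the scatter. A similar outcome is therefore expected here, with a step of a 1.4-fold higher number from compound 2 to compound 3 (0.13 log units; within the scatter) that is not expected to exceed the scatter in this assay. Compound 3 is thus expected to give 0.015 h, with a range from 0.005 h to 0.05 h.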

Compound 3, half-life: 0.0362 h
Compound 3: the middle estimate sits 2.4-fold (0.38 log units) below what was measured; the measured number falls inside the stated range.
By their numbers in this assay, from the lowest: compounds 1 and 2 (each within the scatter of the next); then compound 3.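

At this carbonyl carbon, the swap now shows up in the read-out: in this assay there is a 3.3-fold higher number from compound 2 to compound 3 (0.52 log units; beyond the scatter) and also a 5.6-fold higher number from compound 1 to compound 3 (0.75 log units; beyond the scatter). So this one position can move the half-life beyond the scatter, which the pair of compound 1 and compound 2 could not show, and of the three groups seen here, 4-methylphenyl goes with the longest half-life. Nothing available here explains why the half-life changes with this group.

The compounds shown leave open whether the six-membered ring alone or its methyl group goes with the longer half-life, a question that a plain phenyl on this carbonyl carbon would help to settle. They also leave open how a longer chain such as butyl would compare with ethyl here.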